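Methoxy for fluoro on an inactive benzoxazole amide series

The source may report more compounds than this note shows. Statements on the series, on what has been measured and on what is new or still open speak of the compounds shown alone.

Measured compounds:
compound 1, `C[C@H](Oc1cccc(Cl)c1Cl)C(=O)Nc1ccc2oc(-c3ccc(F)cc3)nc2c1`: > 5000 nM
compound 2, `C[C@H](Oc1cccc(F)c1F)C(=O)Nc1ccc2oc(-c3ccncc3)nc2c1`: > 5000 nM
compound 3, `COc1ccc(OC(C)C(=O)Nc2ccc3oc(-c4ccncc4)nc3c2)cc1`: > 5000 nM

In an assay on isolated protein for inhibition of GMP reductase 2 (Homo sapiens), read by spectrophotometry (a higher number here means a weaker inhibitor, a lower number a stronger inhibitor), compound 1 reaches only the limit of the assay, > 5000 nM, so no inhibition constant is known for it. Compound 2 likewise stops at the limit in this assay, > 5000 nM. Compound 3 also sits at the limit in this assay, > 5000 nM. For the measured compounds named here, all three values thus rest on (the limit of > 5000 nM in this assay, at which 3 of the 3 values shown sit), and no measured step between two compounds is available to size the effect of any change.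

Compound 4, `COc1ccc(-c2nc3cc(NC(=O)[C@H](C)Oc4cccc(Cl)c4Cl)ccc3o2)cc1`, has yet to be measured in this assay. It differs from compound 1 by methoxy in place of fluoro on an aromatic carbon. With every measured compound at the limit, there is no evidence that this change in isolation moves the inhibition constant, and the step from compound 1 to compound 4 is expected to be none beyond the scatter, most likely a limit again, a step that the limit leaves unreadable from compound 1 to compound 4. Compound 4 is therefore estimated at 9000 nM, within 3000 nM to 30000 nM.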

Compound 4, inhibition constant: > 5000 nM
Compound 4 gave a limit, no number (the forecaster's own chance of this, stated with the estimate: 80%); the middle value is on the limit's open side.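

In this assay compound 1 and compound 4 both stop at a limit, so no step can be read for 4-fluorophenyl to 4-methoxyphenyl: the limit of > 5000 nM in this assay, at which 4 of the 4 values shown sit. The compounds shown leave open how large an inhibition constant any of them has, and whether this change alters it.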